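Removing a Methyl Group at Two Different Places

The source may hold more compounds than are shown below. What is called first, only, known or untested is meant among the compounds shown, and "the series" means these compounds.

Three compounds have been measured in a functional assay on K562 cells (Homo sapiens) for cytotoxicity, read by trypan blue exclusion, with a stated time of 96 h; a lower number here means a stronger inhibitor, a higher number a weaker inhibitor:

Compound 1, `COc1cc(OC)c(/C=C/S(=O)(=O)Cc2ccc(OC)c(N)c2)c(OC)c1`: 2.5 nM
Compound 2, `COc1ccc(CS(=O)(=O)/C=C/c2c(OC)cc(O)cc2OC)cc1N`: 300 nM
Compound 3, `COC(=O)CNc1cc(CS(=O)(=O)/C=C/c2cc(OC)c(OC)c(OC)c2)ccc1OC`: 30000 nM

Compound 4, `COc1ccc(CS(=O)(=O)/C=C/c2cc(OC)c(OC)c(OC)c2)cc1NCC(=O)O`, has not yet been measured. It comes from compound 3 by hydrogen in place of methyl on an oxygen next to a carbonyl group. The same kind of change, (hydrogen in place of methyl on an oxygen on an aromatic ring), turns compound 1 into compound 2 and gave a 120-fold higher number from compound 1 to compound 2 (2.08 log units; beyond the scatter). The surroundings are not the same: in the first pair the oxygen is on an aromatic ring whose other neighbours are aromatic carbon, in the second it is next to a carbonyl group whose other neighbours are carbonyl carbon. The difference between the core of compound 1 and the core of compound 3 is not broken down here. Because compound 3 in this assay already gives 30000 nM, only a modest further weakening is expected, a 2.0-fold higher number from compound 3 to compound 4 (0.30 log units; within the scatter). Compound 4 is expected to give 60000 nM, within a range from 15000 nM to 300000 nM.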

Compound 4, half-maximal inhibitory concentration: 3000 nM
The estimate for compound 4 lay 20-fold (1.30 log units) above the measured number; the whole stated range lies above it.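

In this assay, hydrogen in place of methyl on an oxygen next to a carbonyl group gives a 10-fold lower number from compound 3 to compound 4 (1.00 log units; beyond the scatter). Set beside the same swap on an oxygen on an aromatic ring, the change does not carry over from one core to the other in size or in direction: the same change on two cores in this assay, a 120-fold higher number (2.08 log units; beyond the scatter) from compound 1 to compound 2 and a 10-fold lower number (1.00 log units; beyond the scatter) from compound 3 to compound 4, 1200-fold (3.08 log units) apart, beyond the scatter of two such steps. The two pairs differ both in their core and in the surroundings of the oxygen, methoxy to hydroxy in one and methoxycarbonyl to carboxy in the other, and these two steps cannot say which of the two matters.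

The compounds shown leave open how an amide or a longer chain in place of the carboxymethyl group would read in this assay. They also leave open how the carboxymethyl group would read on the core of compound 1.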